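This account rests on a few compounds, and the source may have more. Where it says the series, first, only, none or still open, it means among the compounds named here.

Of the compounds shown here, three have so far been tested in a functional assay on the whole organism (strain albino) for inhibition, with Rattus norvegicus as the target, read by paw edema, with a stated time of 5 h, at a dose of 0.28 mmol/kg by the oral route; a lower number here means less inhibition, a higher number more inhibition at the dose given (going by the name of the read-out). Compound 1 `COc1ccc(-c2nnc(SC/C(=N/O)c3ccccc3)n2-c2ccccc2)cc1` gives 73% in this assay. Compound 3 `COc1ccc(-c2nnc(SCC(=O)c3ccccc3)n2-c2ccccc2)cc1` shares the core of compound 1 and differs from it in a single place: a group of 8 heavy atoms (7 carbon, 1 oxygen; one six-membered aromatic ring of carbon only) in place of a group of 9 heavy atoms (7 carbon, 1 nitrogen, 1 oxygen; one six-membered aromatic ring of carbon only), on a saturated chain carbon bound to a sulfur. This one change produced a step of a number 12 percentage points lower from compound 1 to compound 3 (beyond the scatter) in this assay, so compound 3 gives 61%.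

Compound 2 `C=CCn1c(SC/C(=N/O)c2ccccc2)nnc1-c1cc(OC)c(OC)c(OC)c1` is built on a different core, and the difference between the two cores is not broken down here. In this assay compound 2 gives 77%, a number that lies within the usual scatter of the value of compound 1, so no order between these two can be claimed.

Compound 4 `C=CCn1c(SCC(=O)c2ccccc2)nnc1-c1cc(OC)c(OC)c(OC)c1` has not yet been measured. It stands to compound 2 exactly as compound 3 stands to compound 1: a group of 8 heavy atoms (7 carbon, 1 oxygen; one six-membered aromatic ring of carbon only) in place of a group of 9 heavy atoms (7 carbon, 1 nitrogen, 1 oxygen; one six-membered aromatic ring of carbon only), on a saturated chain carbon bound to a sulfur. The place of the change is the same in both pairs, so this is the same change carried over to the other core. For the measured compounds named here, the only measured example of it is the modest drop seen from compound 1 to compound 3, which lies beyond the scatter. On that basis a step of similar size is expected, namely a number 12 percentage points lower from compound 2 to compound 4 (beyond the scatter), and this expectation rests on the step of a number 12 percentage points lower from compound 1 to compound 3 (beyond the scatter). Compound 4 is therefore estimated at 65% in this assay, with a likely range from 55% to 75%.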

Compound 4, a percentage reported as inhibition, in the whole organism at one dose (the size of the read-out at that dose, not a potency): 60%
Estimate against measurement, compound 4: 5 percentage points above; the range from low to high includes it.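

In this assay, putting benzoyl in place of the group with no common name, on a saturated chain carbon bound to a sulfur, comes with a number 17 percentage points lower from compound 2 to compound 4 (beyond the scatter). Set beside the same change on the core of compound 1, the two steps point the same way and cannot be told apart in size: the same change on two cores in this assay, a number 12 percentage points lower (beyond the scatter) from compound 1 to compound 3 and a number 17 percentage points lower (beyond the scatter) from compound 2 to compound 4, 5 percentage points apart, within the scatter of two such steps This shows that in this small series the change carried over from one core to the other with a similar result, but two pairs are too few to show that it would do so on any further core, and they do not reveal why the number falls.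

The compounds shown leave open what other groups at this place would do, for instance an amine, a carboxylic acid or a longer chain in place of the benzoyl group. They also leave open which part of the difference between the two cores matters on its own, as the cores differ in more than one place and no compound shown separates those differences.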